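Amide nitrogen substituent: cyclopropylmethyl to cyclopropyl

This account rests on a few compounds, and the source may have more. Where it says the series, first, only, none or still open, it means among the compounds named here.

Measured so far:
compound 1, `CN(Cc1ccccc1)C(=O)c1ccc(-c2cc(C3=CC(=O)C=CC3=O)no2)s1`, 11000 nM
compound 2, `COc1ccc(OC)c(-c2cc(-c3ccc(C(=O)NCC4CC4)s3)on2)c1`, reported only as a limit, > 30000 nM

In a functional assay on PC-3 cells (Homo sapiens) for cytotoxicity, read by XTT assay, with a stated time of 72 h (a higher number here means a weaker inhibitor, a lower number a stronger inhibitor), compound 1 gives 11000 nM. For compound 2 only a limit is known, > 30000 nM, as the limit of > 30000 nM in this assay, at which 1 of the 2 values shown sits, records. Compound 3, `COc1ccc(OC)c(-c2cc(-c3ccc(C(=O)NC4CC4)s3)on2)c1`, differs from compound 2 by cyclopropyl in place of cyclopropylmethyl on an amide-type nitrogen. Going by the values given here, no pair of measured compounds spans this change, so the expected step of a number no higher from compound 2 to compound 3 (the limit leaves the size open) is none beyond the scatter, in no particular direction. Compound 3 is therefore expected to stay at the limit of this assay. Compound 3 is estimated at 30000 nM, with a range from 10000 nM to 100000 nM.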

Compound 3, half-maximal inhibitory concentration: 7800 nM
For compound 3 the middle estimate is 3.8-fold (0.59 log units) above the measured one; measured number below the stated range.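

In this assay, replacing cyclopropylmethyl with cyclopropyl on the amide-type nitrogen gives an at least 3.8-fold lower number from compound 2 to compound 3 (0.58 log units; beyond the scatter). Going by these compounds alone, this is the first sign that the read-out responds to this substituent, which the earlier compounds, differing in more than one place, could not show. The size of the step stays open because compound 2 is recorded only as a limit: the limit of > 30000 nM in this assay, at which 1 of the 3 values shown sits.

Still open, going by these compounds, is how an isopropyl group, a longer chain or a chain carrying an amine on this nitrogen would read. Also open, on these data alone, is whether the same change acts alike on the core of compound 1.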